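Bromo in Place of Methoxy on the Methylated Core

A few compounds are considered here, and "the series" means these few. Any claim that something is new, unique, unknown or untested is made for them only; others in the source may bear on it.

Compound 1 `COc1ccc(-n2ccc(=O)c(C(=O)Nc3ccc(Oc4ccnc5[nH]ccc45)c(F)c3)n2)cc1`, compound 2 `O=C(Nc1ccc(Oc2ccnc3[nH]ccc23)c(F)c1)c1nn(-c2ccc(Br)cc2)ccc1=O` and compound 3 `COc1ccc(-n2ccc(=O)c(C(=O)Nc3ccc(Oc4ccnc5c4ccn5C)c(F)c3)n2)cc1` share one core and have been tested in a functional assay on HepG2 cells (Homo sapiens) for cytotoxicity, read by MTT assay, with a stated time of 72 h; a higher number here means a weaker inhibitor, a lower number a stronger inhibitor; compound 4 `Cn1ccc2c(Oc3ccc(NC(=O)c4nn(-c5ccc(Br)cc5)ccc4=O)cc3F)ccnc21` has not. In this assay compound 1 gives > 60000 nM, which is a limit of the assay and not a number. Compound 2 gives 68000 nM in this assay. Compound 3 gives > 60000 nM, again a limit rather than a measured number.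

Compound 2 differs from compound 1 by bromo in place of methoxy on an aromatic carbon, and the step that the limit leaves unreadable from compound 1 to compound 2. Compound 3 differs from compound 1 by methyl in place of hydrogen on an aromatic nitrogen, which is also how the core of compound 3 differs from the core of compound 1; the step that the two limits leave unreadable from compound 1 to compound 3. Both steps are left unreadable because of the limit of > 60000 nM in this assay, at which 2 of the 3 values shown sit.

Compound 4 differs from compound 3 by bromo in place of methoxy on an aromatic carbon. Since the place is described in the same words as for the change from compound 1 to compound 2, this is the same change, made on the core of compound 3. For compound 4 the step that the limit leaves unreadable from compound 3 to compound 4 is expected, resting on compound 2 with 68000 nM, which shows that this change leaves the compound a weak inhibitor. Compound 4 is therefore estimated at 70000 nM, with a range from 40000 nM to 130000 nM, and the assay may well report only a limit.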

Compound 4, half-maximal inhibitory concentration: > 60000 nM
Compound 4 was reported as a limit; the forecaster's own chance of this, stated with the estimate: 50%; the middle value does not contradict the limit.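

In this assay compound 4 gives > 60000 nM, which is a limit of the assay and not a number. The steps to compound 4 from compound 2 and from compound 3 therefore have no readable size, because the values run into the same ceiling: the limit of > 60000 nM in this assay, at which 3 of the 4 values shown sit. The compounds shown leave open whether either change, bromo in place of methoxy or methyl on the aromatic nitrogen, shifts the result in this assay at all.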